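The compounds below may be only part of what the source reports. "The series", "measured", "known", "first", "only" and "open" are said of these compounds alone.

Measured compounds in a functional assay on T47D cells (Homo sapiens) for inhibition, read by sulforhodamine B assay, with a stated time of 48 h, tested at 10 uM; a higher number here means more inhibition of growth at the concentration tested, a lower number less inhibition of growth:
compound 1 `CC(=O)c1ccc(Nc2ccnc(SCC(=O)c3ccc(Br)cc3)n2)cc1`: 44%
compound 2 `CCOC(=O)c1ccc(Nc2ccnc(SCC(=O)c3ccc([N+](=O)[O-])cc3)n2)cc1`: 60%
compound 3 `CCOC(=O)c1ccc(Nc2ccnc(SCC(=O)c3ccc(C#N)cc3)n2)cc1`: 90%

Compound 1 stands lowest of the three numbers; compound 2 lies above it by a gap beyond the scatter, and compound 3 lies furthest above it, also beyond the scatter. For the measured compounds named here, the only single-point step among the measured compounds is a number 30 percentage points higher from compound 2 to compound 3 (beyond the scatter), cyano in place of nitro on an aromatic carbon, and it runs between two compounds that carry the ester rather than the acetyl of compound 1.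

Compound 4 `CC(=O)c1ccc(Nc2ccnc(SCC(=O)c3ccc(-c4ccccc4)cc3)n2)cc1` differs from compound 1 by phenyl in place of bromo on an aromatic carbon, para to a large group. Going by the values given here, no measured step exchanges bromo for anything, so no step bears directly on this change; the step from compound 2 to compound 3 shows only that an exchange of the group on that aromatic carbon can shift this assay by a modest amount in either direction. The expectation is therefore a step of a number 6 percentage points higher from compound 1 to compound 4 (within the scatter), not clearly beyond the scatter, with direction open. Compound 4 is estimated at 50%, with a range from 25% to 75%.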

Compound 4, percent growth inhibition at one concentration: 29%
Compound 4: middle estimate off by 21 percentage points, on the high side; the measured number falls inside the stated range.
By their numbers in this assay, from the lowest: compound 4; then compound 1; then compound 2; then compound 3.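

In this assay, phenyl in place of bromo on an aromatic carbon, para to a large group, gives a number 15 percentage points lower from compound 1 to compound 4 (beyond the scatter). For the compounds shown here, this is the first measured exchange at this position among the compounds carrying the acetyl, and it shows that the number can fall there, whereas the earlier step, a number 30 percentage points higher from compound 2 to compound 3 (beyond the scatter), ran upward between two compounds carrying the ester. Nothing at hand accounts for the fall.

Going by these compounds, whether an amine, a carboxylic acid or a methoxy group on this aromatic carbon would give a number above or below that of compound 1 remains open. Also open, on these data alone, is whether phenyl in place of bromo would give a step of the same direction and size with the ester in place of the acetyl.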